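Series notes: isobutyl for tert-butyl, outlook for compound 4

A few compounds are considered here, and "the series" means these few. Any claim that something is new, unique, unknown or untested is made for them only; others in the source may bear on it.

Measured so far in a functional assay on the whole organism (blood, strain Wistar-Okamoto) with Rattus norvegicus as the target, with a stated time of 5 days; a higher number here means that more compound is needed for the effect, a lower number that less compound is needed:
compound 1 `CC(C)CC(C)(C)/N=C(\NC#N)Nc1cccnc1` gives 2.5 mg/kg
compound 2 `CC(C)(C)C(C)(C)/N=C(\NC#N)Nc1cccnc1` gives 50 mg/kg
compound 3 `CC(C)(C)C(C)(C)/N=C(\NC#N)Nc1ccncc1` gives 20 mg/kg

Compound 3 and compound 2 carry the same tert-butyl group and differ only in the core: pyridin-4-yl in place of pyridin-3-yl on an amine nitrogen. That difference gives a 2.5-fold lower number from compound 2 to compound 3 (0.40 log units; beyond the scatter). Compound 4 `CC(C)CC(C)(C)/N=C(\NC#N)Nc1ccncc1` is not yet measured in this assay; it differs from compound 3 by isobutyl in place of tert-butyl on a saturated chain carbon bound to a double-bonded nitrogen and two saturated chain carbons. The same change has been made once before, from compound 2 to compound 1: isobutyl in place of tert-butyl on a saturated chain carbon bound to a double-bonded nitrogen and two saturated chain carbons, which gave a 20-fold lower number from compound 2 to compound 1 (1.30 log units; beyond the scatter). The place of the change reads the same word for word in both pairs, so it is the same change, now on the core of compound 3. Compound 4 is expected to show a step of a 13-fold lower number from compound 3 to compound 4 (1.12 log units; beyond the scatter) in this assay, a little smaller than the earlier one, because a 20-fold lower number from compound 2 to compound 1 (1.30 log units; beyond the scatter) rests on a single pair and compound 3 already starts from a lower number than compound 2. The estimate for compound 4 in this assay is 1.5 mg/kg, with a range from 0.5 mg/kg to 5 mg/kg.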

Compound 4, minimum effective dose: 20 mg/kg
Compound 4: the middle estimate sits 13-fold (1.12 log units) below what was measured; measured number above the stated range.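

In this assay, isobutyl in place of tert-butyl gives no change at the digits printed from compound 3 to compound 4 (within the scatter), so the large step seen on the core of compound 1 does not carry over to the core of compound 3: the same change on two cores in this assay, a 20-fold lower number (1.30 log units; beyond the scatter) from compound 2 to compound 1 and no change at the digits printed (within the scatter) from compound 3 to compound 4, 20-fold (1.30 log units) apart, beyond the scatter of two such steps Read the other way round, pyridin-4-yl in place of pyridin-3-yl gives an 8.0-fold higher number from compound 1 to compound 4 (0.90 log units; beyond the scatter) with the isobutyl group, opposite in direction to the step seen with tert-butyl: the same change on two cores in this assay, a 2.5-fold lower number (0.40 log units; beyond the scatter) from compound 2 to compound 3 and an 8.0-fold higher number (0.90 log units; beyond the scatter) from compound 1 to compound 4, 20-fold (1.30 log units) apart, beyond the scatter of two such steps The two changes therefore do not add up independently across these four compounds, but the set is a single square with one value per compound, and it shows neither why the steps differ nor whether the same holds for any other group.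

As far as these compounds go, it remains open whether a longer chain, or a cyclohexyl group, in place of isobutyl would follow the core of compound 1 or the core of compound 3 in this assay. From the compounds shown here alone, whether any other group on the core of compound 3 gives a number lower than that of compound 3 also stays open.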